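Swapping the Aryl Group on a Shared Core

The source may hold more compounds than are shown below. What is called first, only, known or untested is meant among the compounds shown, and "the series" means these compounds.

Compound 1 `CC(C)(C)n1ncc(OCc2nnc(-c3ccccc3Cl)o2)c(Cl)c1=O` was examined in a functional assay on the whole organism for inhibition, with Mythimna separata as the target, with a stated time of 5 days (a lower number here means that less compound is needed, a higher number that more compound is needed for the effect), where compound 1 gives 61200 nM. Among the numbers shown this is the lowest of two, the nearest being compound 2 `CC(C)(C)n1ncc(OCc2nnc(-c3cc(F)c(Cl)cc3Cl)s2)c(Cl)c1=O`, which in this assay gives 67100 nM; that gap lies within the scatter, so no order can be read between the two. Compound 3 `CCn1ncc(OCc2nnc(-c3ccc(F)cc3)o2)c(Cl)c1=O` reaches only a limit in this assay, namely > 299000 nM. That value is the limit of > 299000 nM in this assay, at which 1 of the 3 values shown sits.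

Compound 4 `CC(C)(C)n1ncc(OCc2nnc(-c3c(F)cccc3F)o2)c(Cl)c1=O` has not yet been measured. It differs from compound 1 in one place: 2,6-difluorophenyl in place of 2-chlorophenyl on an aromatic carbon. Within the data shown here, no measured pair shows this change, so its size is uncertain; with compound 1 at 61200 nM and compound 2 at 67100 nM both sitting far up the scale, the step is expected to be modest and of no sure direction. Compound 4 is therefore expected to give about 80000 nM in this assay, between 25000 nM and 300000 nM. The expected step is a 1.3-fold higher number from compound 1 to compound 4 (0.12 log units; within the scatter).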

Compound 4, half-maximal effective concentration: 45400 nM
Beside the measured number, compound 4's estimate is 1.8-fold (0.25 log units) above it, and the stated range covers the measured number.
By their numbers in this assay, from the lowest: compounds 4, 1 and 2 (each within the scatter of the next). At a limit, above all of these: compound 3.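

Among these compounds, the swap gives the first single-place comparison in this set: in this assay the step is a 1.3-fold lower number from compound 1 to compound 4 (0.13 log units; within the scatter). On this aromatic carbon of the five-membered aromatic ring, 2,6-difluorophenyl can therefore stand in for 2-chlorophenyl with no change that can be read from the scatter, so exchanging one chlorine for two fluorines on the phenyl ring does not separate these two compounds. Nothing measured here gives a reason for this outcome.

Both phenyl groups in this step carry only halogens, so the compounds shown leave open how this position would respond to a methoxy group, an amine or a carboxylic acid on that ring. From the compounds shown here alone, compound 2 and compound 3 each differ from compound 1 in more than one place, so what the sulfur-containing ring or the ethyl chain contributes alone also stays open.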